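Ring-oxygen substituent swap on the shared core

The source may hold more compounds than are shown below. What is called first, only, known or untested is meant among the compounds shown, and "the series" means these compounds.

Compound 2 `CC(C)=CCC/C(C)=C/CC1Cc2c(OCCCNC(=O)c3ccco3)cc(=O)n(CCCO)c2CC1(C)C` gives 2.8% in a functional assay on PANC-1 cells (Homo sapiens) for inhibition, read by MTT assay, with a stated time of 24 h, tested at 10 uM; a higher number here means more inhibition at the concentration tested (going by the name of the read-out), a lower number less inhibition; it stands second highest of the three numbers, with compound 1 `CC(C)=CCC/C(C)=C/CC1Cc2c(O)cc(=O)n(CCCO)c2CC1(C)C` giving 0% and compound 3 `CC(C)=CCC/C(C)=C/CC1Cc2c(OCCCOc3ccc([N+](=O)[O-])cc3)cc(=O)n(CCCO)c2CC1(C)C` giving 9.8%, each within the scatter of compound 2. The two measured steps, a number 2.8 percentage points higher from compound 1 to compound 2 (within the scatter) and a number 7 percentage points higher from compound 2 to compound 3 (within the scatter), show that changes at this oxygen have so far moved the read-out within the scatter only. Compound 4 `CC(C)=CCC/C(C)=C/CC1Cc2c(OC(=O)Nc3cccc(F)c3)cc(=O)n(CCCO)c2CC1(C)C` differs from compound 2 by (3-fluorophenyl)carbamoyl in place of 3-(((furan-2-yl)carbonyl)amino)propyl on an oxygen on an aromatic ring. Neither measured step covers this change; both bear on it only as changes at the same oxygen, and both were small. A step of a number 2.2 percentage points higher from compound 2 to compound 4 (within the scatter) is therefore expected, none beyond the scatter. For compound 4 the estimate is 5%, with a range from 0% to 20%.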

Compound 4, a percentage reported as inhibition, at one concentration (the size of the read-out at that concentration, not a potency): 0%
Compound 4: middle estimate off by 5 percentage points, on the high side; measured number inside the range.
By their numbers in this assay, from the lowest: compounds 1, 4, 2 and 3 (each within the scatter of the next).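

In this assay, (3-fluorophenyl)carbamoyl on this oxygen gives a number 2.8 percentage points lower from compound 2 to compound 4 (within the scatter), and in place of the hydrogen it gives no change at the digits printed from compound 1 to compound 4 (within the scatter). The series at this oxygen now includes a carbamoyl group joined directly, with no propyl chain, and this group too stays within the scatter of both compounds. No data at hand account for these small steps. From the compounds shown here alone, it remains open whether a primary amine, a carboxylic acid or a longer chain on this oxygen would give a step beyond the scatter.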